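This account rests on a few compounds, and the source may have more. Where it says the series, first, only, none or still open, it means among the compounds named here.

Measured compounds:
- Compound 1, `Cc1nnc(SCC(=O)Nc2ccc(-c3nc(-c4ccccc4)c(-c4ccccc4)n3C)cc2)s1`: 83.4%
- Compound 2, `Cn1ccnc1SCC(=O)Nc1ccc(-c2nc(-c3ccccc3)c(-c3ccccc3)n2C)cc1`: 43.4%
- Compound 3, `CN1CCN(CC(=O)Nc2ccc(-c3nc(-c4ccccc4)c(-c4ccccc4)n3C)cc2)CC1`: 46.2%

All three were tested in a functional assay on MCF7 cells (Homo sapiens) for cytotoxicity, read by MTT assay, with a stated time of 24 h, tested at 32 ug/mL; on this read-out lower numbers stand for a weaker effect and higher numbers for a stronger effect at the one concentration tested. Compound 1 gives the highest number, and the two steps away from it are both large: a number 40 percentage points lower from compound 1 to compound 2 (beyond the scatter) and a number 37.2 percentage points lower from compound 1 to compound 3 (beyond the scatter). Between the other two there is no real separation, since a number 2.8 percentage points higher from compound 2 to compound 3 (within the scatter). Compound 3 therefore stands second of three, close to compound 2 and far from compound 1.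

Compound 4, `Cn1c(-c2ccc(NC(=O)CN3CCN(Cc4ccc(Cl)cc4)CC3)cc2)nc(-c2ccccc2)c1-c1ccccc1`, has not yet been measured in this assay. It differs from compound 3 in one place: 4-chlorophenyl in place of hydrogen on a saturated chain carbon bound to an amine nitrogen in a ring.

Among the compounds with values here, none of the measured steps touches this position. The two steps that end at compound 3 exchange the whole group attached to the saturated chain carbon bound to the carbonyl carbon, while the step from compound 3 to compound 4 adds a ring onto the methyl that sits on the ring nitrogen, a change of a different kind. The data give no guide to its direction, so the expectation rests on compound 3 alone, with a wide range to allow for either outcome.

For compound 4 the expected step is a number 3.8 percentage points higher from compound 3 to compound 4 (within the scatter). Compound 4 is estimated at 50%, with a range from 25% to 78%.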

Compound 4, a percentage reported as activity, at one concentration (the size of the read-out at that concentration, not a potency): 52.8%
For compound 4 the middle estimate is 2.8 percentage points below the measured one, within the range that was stated.
By their numbers in this assay, from the lowest: compounds 2, 3 and 4 (each within the scatter of the next); then compound 1.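

In this assay, going from methyl to 4-chlorobenzyl gives a number 6.6 percentage points higher from compound 3 to compound 4 (within the scatter), so adding 4-chlorophenyl, with its 7 heavy atoms, on a saturated chain carbon bound to an amine nitrogen in a ring produces no change that can be told apart from the usual scatter. Within the data shown here, the earlier steps exchanged the whole group on the saturated chain carbon bound to a carbonyl carbon, whereas this one keeps that group's piperazine and extends it at its far end, the first information on that position; at this single concentration, the read-out tolerates a substantial addition there. Nothing measured here bears on the reason for this result.

A plain benzyl group at this position would show whether the chlorine makes any difference of its own, and a carboxylic acid or a longer chain carrying the same ring would show whether other additions there move the number beyond the scatter. Going by these compounds, each compound is also represented by a reading at one concentration, so how compound 3 and compound 4 compare in potency remains open.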